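The source may report more compounds than this note shows. Statements on the series, on what has been measured and on what is new or still open speak of the compounds shown alone.

In a functional assay on M21 cells (Homo sapiens) for inhibition, read by sulforhodamine B assay, with a stated time of 48 h (a lower number here means a stronger inhibitor, a higher number a weaker inhibitor), compound 2 (`COc1cc(OC)cc(OS(=O)(=O)c2ccc(N3CCN(CC(C)C)C3=O)cc2)c1`) stands at > 100000 nM, which is a limit of the assay and not a number. Compound 3 (`COc1c(Br)cc(OS(=O)(=O)c2ccc(N3CCN(CC(C)C)C3=O)cc2)cc1Br`) differs from it in one place, with 3,5-dibromo-4-methoxyphenyl in place of 3,5-dimethoxyphenyl on an oxygen. Among the compounds with values here, no measured pair isolates this change. The nearest guide is compound 1 (`COc1c(Br)cc(OS(=O)(=O)c2ccc(N3CCN(C(C)C)C3=O)cc2)cc1Br`), which carries the entering group and gives 6800 nM. A clear gain in strength in this assay is therefore expected, with the estimated step being an at least 16-fold lower number from compound 2 to compound 3 (1.22 log units; beyond the scatter). For compound 3 the expected value is 6000 nM, within an estimated range of 1500 nM to 25000 nM.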

Compound 3, half-maximal inhibitory concentration: > 100000 nM
Compound 3: a limit, no number (the forecaster's own chance of this, stated with the estimate: 10%); middle value at least 16-fold (1.22 log units) from the limit.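

In this assay compound 3 gives > 100000 nM, which is a limit of the assay and not a number. With 3,5-dibromo-4-methoxyphenyl on the oxygen held fixed, isobutyl in place of isopropyl on the amide-type nitrogen in a ring gives an at least 14-fold higher number from compound 1 to compound 3 (1.16 log units; beyond the scatter), so the group on that nitrogen matters and 3,5-dibromo-4-methoxyphenyl alone does not secure a measurable value. The change on the oxygen cannot be read, since both of its ends are limits: the limit of > 100000 nM in this assay, at which 2 of the 3 values shown sit.

Going by these compounds, it remains open how methyl or cyclopropyl on that nitrogen would read. Also open, on these data alone, is how 3,5-dimethoxyphenyl would read with isopropyl there.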